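The source may report more compounds than this note shows. Statements on the series, on what has been measured and on what is new or still open speak of the compounds shown alone.

The measured compounds:
compound 1, `CN(Cc1ccc2nccn2c1)c1nnc(-c2ccc(C3CC3)cc2)o1`, 20000 nM in an assay on isolated protein for inhibition of tyrosine-protein kinase receptor UFO (Homo sapiens), read by LC-MS; a higher number here means a weaker inhibitor, a lower number a stronger inhibitor
compound 2, `CN(Cc1ccc2nccn2c1)c1nnc(-c2ccc(-c3ccccc3)cc2)o1`, 3160 nM in this assay

Compound 2 holds the lower of the two numbers seen so far in this assay; the step from compound 1 is a 6.3-fold lower number from compound 1 to compound 2 (0.80 log units; beyond the scatter), and no other comparison is at hand. Compound 3, `COc1ccccc1-c1ccc(-c2nnc(N(C)Cc3ccc4nccn4c3)o2)cc1`, has not yet been measured in this assay. It differs from compound 2 in one place: methoxy in place of hydrogen on an aromatic carbon. The change sits on an aromatic carbon of a six-membered aromatic ring of carbon only, on the phenyl that was itself introduced in the step from compound 1 to compound 2.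

Among the measured compounds shown here, no measured step bears directly on this change. For the measured compounds named here, the one step known, a 6.3-fold lower number from compound 1 to compound 2 (0.80 log units; beyond the scatter), concerns a different group at a different position and gives no guidance on a methoxy added to the outer ring. With nothing to anchor a direction, a step of a 1.3-fold lower number from compound 2 to compound 3 (0.10 log units; within the scatter) is expected, which stays within the usual scatter. Compound 3 is therefore estimated at 2500 nM, within a range of 800 nM to 8000 nM.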

Compound 3, half-maximal inhibitory concentration: 1580 nM
The estimate for compound 3 lay 1.6-fold (0.20 log units) above the measured number, and the stated range covers the measured number.
By their numbers in this assay, from the lowest: compounds 3 and 2 (each within the scatter of the next); then compound 1.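

In this assay, the outer phenyl takes a methoxy on an aromatic carbon ortho to a large group with no change that can be told from the scatter: the step is a 2.0-fold lower number from compound 2 to compound 3 (0.30 log units; within the scatter), so phenyl and 2-methoxyphenyl cannot be ranked at this place. The benefit seen earlier when cyclopropyl gave way to phenyl also holds for the substituted ring, at a 13-fold lower number from compound 1 to compound 3 (1.10 log units; beyond the scatter), a large step beyond the scatter, so this place can carry more than a bare phenyl without losing that benefit. Nothing at hand gives a measured reason for either step.

Going by these compounds, whether a different group at this place, such as an amine, a carboxylic acid or a longer alkoxy chain, would move the number beyond the scatter stays open, as does the effect of a methoxy on any other carbon of the outer ring. On these data alone, the three compounds differ only at this outer end, so how changes elsewhere on the shared core would affect the number also remains unknown.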